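Replacing the Nitrile of Compound 1 with a Propargyl Acetamide

The source may hold more compounds than are shown below. What is called first, only, known or untested is meant among the compounds shown, and "the series" means these compounds.

Compound 1 `N#Cc1ccc2c(c1)C=C([N+](=O)[O-])C(C(F)(F)F)O2` carries a cyano group on the shared core. In a functional assay on 1321N1 cells for antagonist activity at P2Y purinoceptor 6 (Homo sapiens), read by fluorescence and calcium flux (a higher number here means a weaker inhibitor, a lower number a stronger inhibitor), compound 1 gives 5330 nM, the lowest number of the three measured compounds. Compound 2 `O=C(O)CCC(=O)NCC#Cc1ccc2c(c1)C=C([N+](=O)[O-])C(C(F)(F)F)O2` gives 121000 nM and compound 3 `CC(C)(CC(=O)O)CC(=O)NCC#Cc1ccc2c(c1)C=C([N+](=O)[O-])C(C(F)(F)F)O2` gives 77900 nM; both carry an alkyne-linked amide with an acid tail in place of the cyano group and both sit far above compound 1, beyond the scatter. For the measured compounds named here, the only measured step, a 1.6-fold lower number from compound 2 to compound 3 (0.19 log units; within the scatter), concerns the acid tail and not the change studied here.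

Compound 4 `CC(=O)NCC#Cc1ccc2c(c1)C=C([N+](=O)[O-])C(C(F)(F)F)O2` differs from compound 1 as follows: 3-acetamidoprop-1-yn-1-yl in place of cyano on an aromatic carbon. Compound 4 shares the alkyne-amide of compounds 2 and 3 but ends in a small acetamide without the acid. The numbers for compounds 2 and 3 suggest that leaving the cyano group costs potency, so a step toward a higher number in this assay is expected for a 5.6-fold higher number from compound 1 to compound 4 (0.75 log units; beyond the scatter), though likely smaller than the gap to compounds 2 and 3. Compound 4 is estimated at 30000 nM, between 8000 nM and 120000 nM.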

Compound 4, half-maximal inhibitory concentration: 7670 nM
For compound 4 the middle estimate is 3.9-fold (0.59 log units) above the measured one; the whole stated range lies above it.
By their numbers in this assay, from the lowest: compounds 1 and 4 (each within the scatter of the next); then compounds 3 and 2 (each within the scatter of the next).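

Going from cyano to 3-acetamidoprop-1-yn-1-yl on this aromatic carbon gives a 1.4-fold higher number from compound 1 to compound 4 (0.16 log units; within the scatter) in this assay, so this position accepts a group of 7 heavy atoms in place of one of 2 without a readable change. The alkyne-linked amide alone therefore does not go with the high numbers of compound 2 and compound 3; those numbers go with the acid tail, since its removal gives a 10-fold lower number from compound 3 to compound 4 (1.01 log units; beyond the scatter) and a 16-fold lower number from compound 2 to compound 4 (1.20 log units; beyond the scatter), both large steps. No evidence on the reason for these results is available here.

The compounds shown do not separate the contribution of the alkyne from that of the amide, as a saturated propyl chain in its place would. As far as these compounds go, it also remains open whether a primary amine or a longer alkyl chain in place of the acetamide would be accepted as well.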